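Swapping chloro for methoxy: what to expect for compound 4

The source may report more compounds than this note shows. Statements on the series, on what has been measured and on what is new or still open speak of the compounds shown alone.

- compound 1 `COC(=O)C(Nc1cc(CS(=O)(=O)/C=C/c2c(OC)cc(OC)cc2OC)ccc1OC)c1ccccc1` gives 75 nM
- compound 2 `COC(=O)C(Nc1cc(CS(=O)(=O)/C=C/c2c(OC)cc(OC)cc2OC)ccc1OC)c1ccc(F)cc1` gives 300 nM
- compound 3 `COC(=O)C(Nc1cc(CS(=O)(=O)/C=C/c2c(OC)cc(OC)cc2OC)ccc1OC)c1ccc(Cl)cc1` gives 400 nM

In a functional assay on DU-145 cells (Homo sapiens) for cytotoxicity, read by trypan blue exclusion, with a stated time of 96 h (a lower number here means a stronger inhibitor, a higher number a weaker inhibitor), compound 3 belongs to the upper pair of numbers, well apart from the lowest (a 5.3-fold higher number from compound 1 to compound 3 (0.73 log units; beyond the scatter)). Compound 4 `COC(=O)C(Nc1cc(CS(=O)(=O)/C=C/c2c(OC)cc(OC)cc2OC)ccc1OC)c1ccc(OC)cc1` carries one change (methoxy in place of chloro on an aromatic carbon), methoxy in place of chloro on an aromatic carbon, para to a large group. Fluoro in place of hydrogen gave a rise of like size (a 4.0-fold higher number from compound 1 to compound 2 (0.60 log units; beyond the scatter)), while chloro in place of fluoro gave no step beyond the scatter (a 1.3-fold higher number from compound 2 to compound 3 (0.12 log units; within the scatter)). That single swap of one group for another is thin evidence, but a similar result is expected in this assay here, with a wide range. The estimated step is small (a 1.3-fold lower number from compound 3 to compound 4 (0.12 log units; within the scatter)). Compound 4 is estimated at 300 nM (expected range 110 nM to 800 nM).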

Compound 4, half-maximal inhibitory concentration: 250 nM
Beside the measured number, compound 4's estimate is 1.2-fold (0.08 log units) above it; the range from low to high includes it.
By their numbers in this assay, from the lowest: compound 1; then compounds 4, 2 and 3 (each within the scatter of the next).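

In this assay, methoxy at this place, para to a large group, cannot be told apart from either halogen: the steps (a 1.6-fold lower number from compound 3 to compound 4 (0.20 log units; within the scatter) and a 1.2-fold lower number from compound 2 to compound 4 (0.08 log units; within the scatter)) both lie within the scatter. Against hydrogen the gap remains clear (a 3.3-fold higher number from compound 1 to compound 4 (0.52 log units; beyond the scatter)), so fluoro, chloro and methoxy all give higher numbers than compound 1, despite the difference between these groups. No evidence here accounts for this.

Still open, going by these compounds, is how an amine, a carboxylic acid or a longer chain such as ethoxy would behave at this place. The compounds shown also leave open whether any group here could match or better hydrogen.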